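The source may hold more compounds than are shown below. What is called first, only, known or untested is meant among the compounds shown, and "the series" means these compounds.

Working notes on the series. Going by the values given here, in a functional assay on OVCAR-5 cells (Homo sapiens) for inhibition, read by CCK-8 assay, with a stated time of 72 h, tested at 10 uM (a lower number here means less inhibition of growth, a higher number more inhibition of growth at the concentration tested), compound 1 `CN(C)C(=O)c1cc2cnc(Nc3ccc(NC(=O)C4(C(=O)Nc5cccc(Cl)c5)CC4)cc3)nc2n1C1CCCC1` gives 88.1%, the highest of the three numbers so far, with both gaps beyond the scatter. Compound 3 `CN(C)C(=O)c1cc2cnc(Nc3ccc(NC(=O)C4(C(=O)Nc5ccc(F)cc5)CC4)cc3F)nc2n1C1CCCC1` gives 33%, and compound 2 `Nc1ccc(NC(=O)C2(C(=O)Nc3ccc(F)cc3)CC2)cc1F`, without the shared core, gives 9.7%. Compound 4 `CN(C)C(=O)c1cc2cnc(Nc3ccc(NC(=O)C4(C(=O)Nc5ccccc5)CC4)cc3)nc2n1C1CCCC1` departs from compound 1 by one change: hydrogen in place of chloro on an aromatic carbon. Among the compounds with values here, no single-change step has been measured, so the size remains a judgement. A fall is expected since compound 3 stands at 33% without the chloro. The estimated step is a number 26.1 percentage points lower from compound 1 to compound 4 (beyond the scatter), a fall beyond the scatter. Compound 4 is expected at 62%, with an estimated range of 35% to 85%.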

Compound 4, percent growth inhibition at one concentration: 77.1%
Compound 4: the middle estimate sits 15.1 percentage points below what was measured; the range from low to high includes it.
By their numbers in this assay, from the lowest: compound 2; then compound 3; then compound 4; then compound 1.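

Hydrogen in place of chloro on an aromatic carbon gives the first single-change step of the series in this assay: a number 11 percentage points lower from compound 1 to compound 4 (beyond the scatter). The chloro therefore adds to growth inhibition at this position but is not required for it, as compound 4 without it still gives 77.1%. No measurement at hand bears on the reason for this step.

From the compounds shown here alone, whether a methyl, methoxy or trifluoromethyl group at this position would match the chloro remains open. Also open, going by these compounds, is whether an amine or carboxylic acid there would keep the inhibition.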